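The compounds below may be only part of what the source reports. "The series", "measured", "known", "first", "only" and "open" are said of these compounds alone.

Compound 2 `SC1=NC(n2nc(-c3ccccc3)nc2-c2ccccc2)=CC(c2ccccc2Cl)N1` shows a minimum effective dose of 300 mg/kg in a functional assay on the whole organism with Mus musculus as the target, in the maximal electroshock model, with a stated time of 4 h; a higher number here means that more compound is needed for the effect, a lower number that less compound is needed. Compound 1 `SC1=NC(n2nc(-c3ccccc3)nc2-c2ccccc2)=CC(c2ccc(Cl)cc2)N1` gives 300 mg/kg and compound 3 `COc1ccc(C2C=C(n3cc(-c4ccccc4)nc3-c3ccccc3)N=C(S)N2)cc1` gives 300 mg/kg in this assay, so compound 2 stands level with both. Compound 4 `SC1=NC(n2nc(-c3ccccc3)nc2-c2ccccc2)=CC(c2ccc(-c3ccco3)cc2)N1` differs from compound 2 by 4-(furan-2-yl)phenyl in place of 2-chlorophenyl on a saturated ring carbon. Among the measured compounds shown here, the only measured step that touches this position, no change at the digits printed from compound 1 to compound 2 (within the scatter), exchanged one chlorophenyl for another on the saturated ring carbon and left the dose unchanged. For the measured compounds named here, no measured step introduces a 4-(furan-2-yl)phenyl group, so the three equal doses are the whole basis. Compound 4 is therefore expected to behave like compound 2, with no change at the digits printed from compound 2 to compound 4 (within the scatter) meaning no step beyond the scatter. Compound 4 is estimated at 300 mg/kg in this assay, within a range from 150 mg/kg to 600 mg/kg.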

Compound 4, minimum effective dose: 300 mg/kg
Beside the measured number, compound 4's estimate shows no gap at the digits printed; measured number inside the range.
By their numbers in this assay, from the lowest: compounds 1, 2, 3 and 4 (each within the scatter of the next).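

Putting 4-(furan-2-yl)phenyl in place of 2-chlorophenyl on the saturated ring carbon gives no change at the digits printed from compound 2 to compound 4 (within the scatter) in this assay, and furan-2-yl in place of chloro on the aromatic carbon gives no change at the digits printed from compound 1 to compound 4 (within the scatter). This position therefore takes a second aromatic ring and a hydrogen-bond acceptor with no step beyond the scatter. Nothing at hand offers a reason for this result.

As far as these compounds go, whether an amine or a carboxylic acid on the phenyl ring at this position would shift the dose remains open. So does whether any change here can lower it at all.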